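Trimming the Ether Back to a Free Phenol

The source may report more compounds than this note shows. Statements on the series, on what has been measured and on what is new or still open speak of the compounds shown alone.

Compound 1 `COc1ccc(CN2C(=O)C(=O)c3cc(-c4ccc(OC)cc4)ccc32)cc1` gives 50 nM in a functional assay on HepG2 cells (Homo sapiens) for antiproliferative activity, read by MTT assay, with a stated time of 48 h; on this read-out lower numbers stand for stronger inhibition and higher numbers for weaker inhibition.
Compound 2 `COc1ccc(CN2C(=O)C(=O)c3cc(-c4cc(OC)cc(OC)c4)ccc32)cc1` gives 1200 nM.
Compound 3 `COc1ccc(CN2C(=O)C(=O)c3cc(-c4ccc(OC(C)C)cc4)ccc32)cc1` reports only > 10000 nM, a limit of the assay and not a measured number.

Compound 3 therefore stands at the edge of what this assay can report, at the limit (the limit of > 10000 nM in this assay, at which 1 of the 3 values shown sits). The steps leading to it are clear: an at least 200-fold higher number from compound 1 to compound 3 (2.30 log units; beyond the scatter) and an at least 8.3-fold higher number from compound 2 to compound 3 (0.92 log units; beyond the scatter) both moved toward higher numbers, that is toward weaker inhibition.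

Compound 4 `COc1ccc(CN2C(=O)C(=O)c3cc(-c4ccc(O)cc4)ccc32)cc1` differs from compound 3 by hydrogen in place of isopropyl on an oxygen on an aromatic ring. Going by the values given here, the one measured step that touches this oxygen is an at least 200-fold higher number from compound 1 to compound 3 (2.30 log units; beyond the scatter), where the methyl grew into an isopropyl and the number climbed far beyond the scatter. Among the compounds with values here, the change to compound 4 runs the other way and removes the isopropyl altogether, so a move back toward lower numbers is expected, though no measured compound carries the free hydroxy itself, and the size of the move is uncertain. Compound 4 is expected to land near 400 nM, within a range from 50 nM to 5000 nM. From compound 3 the expected step is an at least 25-fold lower number from compound 3 to compound 4 (1.39 log units; beyond the scatter).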

Compound 4, half-maximal inhibitory concentration: > 10000 nM
Compound 4 ended at the assay's limit; the forecaster's own chance of this, stated with the estimate: 15%; middle value at least 25-fold (1.39 log units) from the limit.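

In this assay, replacing the methyl on this oxygen with hydrogen gives an at least 200-fold higher number from compound 1 to compound 4 (2.30 log units; beyond the scatter), so among compounds 1, 3 and 4 activity is lost whether the group on the oxygen grows to isopropyl or shrinks to hydrogen. The free hydroxy also falls behind the two methoxy groups of compound 2, with an at least 8.3-fold higher number from compound 2 to compound 4 (0.92 log units; beyond the scatter). The step between compound 3 and compound 4 cannot be read, since both values are limits of the assay and not numbers: the limit of > 10000 nM in this assay, at which 2 of the 4 values shown sit.

Going by these compounds, of the three groups on this oxygen, only methyl gives a value short of the limit, but how narrow that preference is remains open. An ethyl on the same oxygen, or an amine in place of the oxygen, would test whether anything other than methyl is tolerated here.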